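Amide chain lengthening in the series

The source may hold more compounds than are shown below. What is called first, only, known or untested is meant among the compounds shown, and "the series" means these compounds.

Compound 1 `CCCCCCC(=O)NCC(C)(C)CC1=C(O)C(=O)c2ccccc2C1=O` and compound 2 `CCCCCCCCCCCC(=O)NCC(C)(C)CC1=C(O)C(=O)c2ccccc2C1=O` share one core and differ only in the length of the amide chain. In an ADME assay on Vero cells (Chlorocebus sabaeus) for cytotoxicity, read by reporter gene assay, with a stated time of 4 days (a higher number here means a weaker inhibitor, a lower number a stronger inhibitor), compound 1 gives 24800 nM, and compound 2 gives 13900 nM. The step of a 1.8-fold lower number from compound 1 to compound 2 (0.25 log units; within the scatter) corresponds to pentyl in place of hydrogen on a saturated chain carbon, six bonds along the chain from a carbonyl carbon. On these two numbers compound 2 stands at the lower one, but its gap to compound 1 is within the scatter. Compound 3 `CCCCCCCCCCCCCC(=O)NCC(C)(C)CC1=C(O)C(=O)c2ccccc2C1=O` continues in the same direction: ethyl in place of hydrogen on a saturated chain carbon, ten or more bonds along the chain from a carbonyl carbon. Among the compounds with values here, the only measured step that bears on this, a 1.8-fold lower number from compound 1 to compound 2 (0.25 log units; within the scatter), involved a larger addition and stayed within the scatter, so the smaller addition here is expected to give no step beyond the scatter in this assay. For compound 3 the estimate is 11000 nM with a range of 5000 nM to 25000 nM. For compound 3 the expected step is a 1.3-fold lower number from compound 2 to compound 3 (0.10 log units; within the scatter).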

Compound 3, half-maximal inhibitory concentration: 9810 nM
For compound 3 the middle estimate is 1.1-fold (0.05 log units) above the measured one; the measured number falls inside the stated range.
By their numbers in this assay, from the lowest: compounds 3, 2 and 1 (each within the scatter of the next, the first and the last beyond it).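

In this assay the ethyl addition on a saturated chain carbon gives a 1.4-fold lower number from compound 2 to compound 3 (0.15 log units; within the scatter) and so cannot be told apart from repeat measurement. Within the data shown here, the heptyl addition, six bonds along the chain from a carbonyl carbon, gives a 2.5-fold lower number from compound 1 to compound 3 (0.40 log units; beyond the scatter) and is the first step in this short series to pass beyond the scatter, although the two shorter steps that make it up each stay within it. No measurement on hand explains this small shift.

From the compounds shown here alone, whether a longer chain would move the number further in this assay remains open. Also open, going by these compounds, is how an amine or a carboxylic acid at the far end of the chain would compare with these plain saturated chains.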